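The source may hold more compounds than are shown below. What is called first, only, known or untested is meant among the compounds shown, and "the series" means these compounds.

Measured so far in a functional assay on U-87MG ATCC cells for antiproliferative activity against U-87 MG (Homo sapiens), read by MTT assay, with a stated time of 48 h, tested at 100 uM; on this read-out higher numbers stand for a weaker effect at the one concentration tested and lower numbers for a stronger effect:

compound 1, `Cc1nc(-c2ccccc2)sc1C(=O)CSc1nc(-c2ccc(Cl)c(Cl)c2)c(C#N)c(=O)[nH]1` — 24.4%
compound 2, `Cc1nc(-c2ccccc2)sc1C(=O)CSc1nc(N)c(C#N)c(-c2ccc(Cl)cc2)n1` — 17.1%
compound 3, `Cc1nc(-c2ccccc2)sc1C(=O)CSc1nc(-c2cccc(Cl)c2)c(C#N)c(=O)[nH]1` — 10%

Compounds 1 and 3 share one core; compound 2 carries a different core, and the difference between the two cores is not broken down here. Compound 2 sits within the scatter of both compound 1 and compound 3 in this assay, so no order among these three can be read from the numbers alone.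

One change is recorded twice in the set. From compound 1 to compound 3 it is hydrogen in place of chloro on an aromatic carbon, and it made a number 14.4 percentage points lower from compound 1 to compound 3 (beyond the scatter). From compound 2 to the unmeasured compound 4, `Cc1nc(-c2ccccc2)sc1C(=O)CSc1nc(N)c(C#N)c(-c2ccccc2)n1`, it is hydrogen in place of chloro on an aromatic carbon. The two places are not the same word for word: in compound 1 the leaving chloro stands ortho to a chloro group and para to a large group, whereas in compound 2 it stands only para to a large group, with no second chloro on that ring. The change is therefore the same kind of change rather than the same one, and it is made on a different core.

For compound 4 the expectation is a step in the same direction, a number 8.1 percentage points lower from compound 2 to compound 4 (within the scatter), resting on the modest lowering seen for compound 3, a number 14.4 percentage points lower from compound 1 to compound 3 (beyond the scatter), and on the starting point of compound 2, 17.1%, which leaves limited room downward. Within the data shown here, compound 4 is therefore estimated at 9%, within 1% and 22%, with the single precedent and the changed surroundings of the place making this a loose estimate.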

Compound 4, a percentage reported as activity, at one concentration (the size of the read-out at that concentration, not a potency): 6.48%
For compound 4 the middle estimate is 2.5 percentage points above the measured one, within the range that was stated.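

In this assay, hydrogen in place of chloro on an aromatic carbon, here the change from 4-chlorophenyl to phenyl, gives a number 10.6 percentage points lower from compound 2 to compound 4 (beyond the scatter). Set beside the earlier step, the change carries from one core to the other with the same direction and with sizes that cannot be told apart: the same change on two cores in this assay, a number 14.4 percentage points lower (beyond the scatter) from compound 1 to compound 3 and a number 10.6 percentage points lower (beyond the scatter) from compound 2 to compound 4, 3.8 percentage points apart, within the scatter of two such steps This supports treating the removal of this chloro as transferable between these two cores in this one read-out, but it rests on only two pairs, at one concentration and without potency values, the places are not identical, as the ring of compound 3 still bears a chloro while that of compound 4 bears none, and nothing here extends the result to any third core or explains why the step occurs.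

The compounds shown hold only chloro or hydrogen at the changed place, so it remains open how a fluoro, a methoxy or an amine there would read on either core. Also open, from the compounds shown here alone, is whether the step would hold with a group other than the unsubstituted phenyl at the far end of the part the compounds share, for example a carboxylic acid on that ring.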